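The source may report more compounds than this note shows. Statements on the series, on what has been measured and on what is new or still open speak of the compounds shown alone.

Compound 1 `CCO/C(O)=C1\C(C)=NC(C)=C(C(=O)OCCCN2C(=O)c3ccccc3S2(=O)=O)C1c1cccc(Cl)c1Cl` and compound 2 `CC1=NC(C)=C(C(=O)OCCCN2C(=O)c3ccccc3S2(=O)=O)C(c2cccc(Cl)c2Cl)/C1=C(\O)OC(C)C` share a core and differ only at one point: methyl in place of hydrogen on a saturated chain carbon bound to an oxygen on an unsaturated carbon and a saturated chain carbon. In a functional assay (aorta) with Oryctolagus cuniculus as the target (a lower number here means a stronger inhibitor, a higher number a weaker inhibitor), compound 1 gives 1.8 nM, and compound 2 gives 2.1 nM, so this exchange made a 1.2-fold higher number from compound 1 to compound 2 (0.07 log units; within the scatter). Compound 3 `CCO/C(O)=C1\C(C)=NC(C)=C(C(=O)OCCCN2C(=O)c3ccccc3S2(=O)=O)C1c1ccccc1C(F)(F)F` carries the same ethoxy group as compound 1 but a different aromatic ring on the core: 2-(trifluoromethyl)phenyl in place of 2,3-dichlorophenyl on a saturated ring carbon. In this assay compound 3 gives 0.8 nM, which made a 2.3-fold lower number from compound 1 to compound 3 (0.35 log units; beyond the scatter). Compound 4 `CC1=NC(C)=C(C(=O)OCCCN2C(=O)c3ccccc3S2(=O)=O)C(c2ccccc2C(F)(F)F)/C1=C(\O)OC(C)C` has not yet been measured. It stands to compound 3 as compound 2 stands to compound 1, with the same change in the same place: methyl in place of hydrogen on a saturated chain carbon bound to an oxygen on an unsaturated carbon and a saturated chain carbon. Because the earlier exchange made a 1.2-fold higher number from compound 1 to compound 2 (0.07 log units; within the scatter), a step of similar size is expected here, so the value of compound 4 is estimated to lie close to that of compound 3, with an expected step of a 1.3-fold higher number from compound 3 to compound 4 (0.10 log units; within the scatter). The estimate for compound 4 in this assay is therefore 1 nM, expected to fall between 0.5 nM and 2 nM.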

Compound 4, half-maximal inhibitory concentration: 2.7 nM
Compound 4: the middle estimate sits 2.7-fold (0.43 log units) below what was measured; measured number above the stated range.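

Swapping ethoxy for isopropoxy gave a step in this assay of a 3.4-fold higher number from compound 3 to compound 4 (0.53 log units; beyond the scatter), so the size of this change did not carry over from one core to the other: the same change on two cores in this assay, a 1.2-fold higher number (0.07 log units; within the scatter) from compound 1 to compound 2 and a 3.4-fold higher number (0.53 log units; beyond the scatter) from compound 3 to compound 4, 2.9-fold (0.46 log units) apart, beyond the scatter of two such steps. Exchanging the aromatic ring also gave a different result once isopropoxy was present, with a step of a 1.3-fold higher number from compound 2 to compound 4 (0.11 log units; within the scatter), so the two changes cannot simply be added together in this series: the same change on two cores in this assay, a 2.3-fold lower number (0.35 log units; beyond the scatter) from compound 1 to compound 3 and a 1.3-fold higher number (0.11 log units; within the scatter) from compound 2 to compound 4, 2.9-fold (0.46 log units) apart, beyond the scatter of two such steps. These four compounds show that the outcome of each change depended on the group at the other site, but they do not show why, and a single set of four cannot tell how general this behaviour is.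

As far as these compounds go, it remains open whether a bulkier or longer group in the same place, such as tert-butoxy or n-butoxy, would follow the steep or the shallow step. From the compounds shown here alone, it is also open how a different aromatic ring, such as 3-nitrophenyl, would respond to the same swap of ethoxy for isopropoxy.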